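Enantiomer of compound 2 in the hydroxylated pipecolic acid series

A few compounds are considered here, and "the series" means these few. Any claim that something is new, unique, unknown or untested is made for them only; others in the source may bear on it.

Among the compounds with values here, two stereoisomers of the shared core have numbers so far. In an assay for inhibition of alpha-N-acetylgalactosaminidase (Gallus gallus), tested at 1000 uM (on this read-out higher numbers stand for more inhibition at the one concentration tested (going by the name of the read-out) and lower numbers for less inhibition), compound 1 `O=C(O)[C@@H]1NC[C@@H](O)[C@@H](O)[C@H]1O` gives 8.2%. In this assay compound 2 `O=C(O)[C@H]1NC[C@@H](O)[C@H](O)[C@@H]1O` gives 11%. Within the data shown here, compound 2 is one of only two measured compounds, and its step from compound 1, a number 2.8 percentage points higher from compound 1 to compound 2 (within the scatter), is within the scatter, so the two cannot be told apart on these numbers.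

Compound 3 `O=C(O)[C@@H]1NC[C@H](O)[C@@H](O)[C@H]1O` differs from compound 2 as follows: the two compounds have the same atoms and bonds and differ only in configuration as drawn: 4 of 4 stereo elements differ (all stereocentres are inverted: mirror images); a stereocentre at a saturated ring carbon is drawn S in compound 2 and R in compound 3; a stereocentre at a saturated ring carbon is drawn R in compound 2 and S in compound 3; a stereocentre at a saturated ring carbon is drawn S in compound 2 and R in compound 3; a stereocentre at a saturated ring carbon is drawn R in compound 2 and S in compound 3. Among the measured compounds shown here, the only measured step that bears on a change of configuration is a number 2.8 percentage points higher from compound 1 to compound 2 (within the scatter), which is within the scatter and rests on (the fact that compounds 1 and 2 differ only in the configuration as drawn). Both measured isomers sit at low inhibition, so a step of no size beyond the scatter is expected from compound 2 to compound 3, a number 1 percentage points lower from compound 2 to compound 3 (within the scatter). Compound 3 is therefore estimated at 10%, within a range from 0% to 25%.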

Compound 3, a percentage reported as inhibition, at one concentration (the size of the read-out at that concentration, not a potency): 4%
Compound 3: the middle estimate sits 6 percentage points above what was measured, and the stated range covers the measured number.
By their numbers in this assay, from the lowest: compounds 3, 1 and 2 (each within the scatter of the next).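

In this assay both members of a mirror-image pair now have numbers, and inverting all the stereocentres gives a number 7 percentage points lower from compound 2 to compound 3 (within the scatter) on this read-out. Inverting a single stereocentre at a saturated ring carbon gives a number 4.2 percentage points lower from compound 1 to compound 3 (within the scatter), so across these three stereoisomers neither one inversion nor all of them moves the number beyond the scatter. These steps speak to configuration alone: the fact that compounds 2 and 3 differ only in the configuration as drawn.

Still open, going by these compounds, is whether any other stereoisomer of the shared core would stand beyond the scatter of these three. Also open, on these data alone, is whether a methyl ester or a primary amide in place of the carboxylic acid, or a longer chain on the amine, would shift the number in this assay at all.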